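Adding a Second Methoxy Group to the Aryl Ring

This account rests on a few compounds, and the source may have more. Where it says the series, first, only, none or still open, it means among the compounds named here.

Measured compounds:
Compound 1 `COc1ccc(/C=N/c2c(C)n(C)n(-c3ccccc3)c2=O)cc1`: 589000000 nM
Compound 2 `Cc1c(/N=C/c2ccccc2Cl)c(=O)n(-c2ccccc2)n1C`: 309000000 nM
Compound 3 `COc1cccc(/C=N/c2c(C)n(C)n(-c3ccccc3)c2=O)c1`: 155000000 nM

In a functional assay on HT-29 cells (Homo sapiens) for cytotoxicity, read by MTT assay, with a stated time of 72 h (a lower number here means a stronger inhibitor, a higher number a weaker inhibitor), compound 3 gives the lowest of the three numbers. Its nearest neighbour is compound 2, and the two lie within the scatter: a 2.0-fold lower number from compound 2 to compound 3 (0.30 log units; within the scatter). Against compound 1 the gap is larger: a 3.8-fold lower number from compound 1 to compound 3 (0.58 log units; beyond the scatter), a modest step. The third measured step, a 1.9-fold lower number from compound 1 to compound 2 (0.28 log units; within the scatter), also sits within the scatter, so the three compounds span only a narrow band.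

Compound 4 `COc1ccc(/C=N/c2c(C)n(C)n(-c3ccccc3)c2=O)cc1OC` is the next compound. It differs from compound 3 in one place: methoxy in place of hydrogen on an aromatic carbon. Within the data shown here, no measured step adds a group; the only one that touches a methoxy group is the swap from compound 1 to compound 3, and it was modest. Compound 4 keeps the methoxy of compound 3 and gains the methoxy pattern of compound 1, so the expectation is a number in this assay between those two, most likely no step beyond the scatter. The expected step is a 1.6-fold higher number from compound 3 to compound 4 (0.21 log units; within the scatter), and compound 4 is estimated at 250000000 nM, with a range from 80000000 nM to 700000000 nM.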

Compound 4, half-maximal inhibitory concentration: 603000000 nM
The estimate for compound 4 lay 2.4-fold (0.38 log units) below the measured number; low and high end bracket the measured number.
By their numbers in this assay, from the lowest: compounds 3, 2, 1 and 4 (each within the scatter of the next, the first and the last beyond it).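

In this assay, methoxy in place of hydrogen at this place, para to a large group, does not act the same way on every partner: one such step gives a 3.9-fold higher number from compound 3 to compound 4 (0.59 log units; beyond the scatter), while the other gives a 1.0-fold higher number from compound 1 to compound 4 (0.01 log units; within the scatter). The second methoxy therefore separates compound 4 from compound 3 but leaves it within the scatter of compound 1, which already carries a methoxy at this place. No measured evidence accounts for this difference between the two steps.

The compounds shown leave open whether this place responds to anything other than methoxy, such as a hydroxyl group, an amine or a longer ethoxy chain. They also leave open whether a single group there, without the methoxy of compound 3, would behave as methoxy does.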